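The source may report more compounds than this note shows. Statements on the series, on what has been measured and on what is new or still open speak of the compounds shown alone.

Measured so far in a functional assay on MCF7 cells (Homo sapiens) for antiproliferative activity, read by MTT assay, with a stated time of 72 h; a lower number here means a stronger inhibitor, a higher number a weaker inhibitor:
compound 1 `CCN(CC)CCNc1cc(C)c2cc(NC(=O)c3ccc(Cl)c(Cl)c3)ccc2n1` gives 1420 nM
compound 2 `CCN1CCN(c2cc(C)c3cc(NC(=O)c4ccc(F)cc4)ccc3n2)CC1` gives 4030 nM
compound 3 `CCN1CCN(c2cc(C)c3cc(NC(=O)c4ccccc4OC)ccc3n2)CC1` gives 13200 nM

Compound 1 stands lowest of the three numbers in this assay; compound 2 is nearest and compound 3 furthest, both beyond the scatter.

The compound under consideration is compound 4 `Cc1cc(N2CCN(C)CC2)nc2ccc(NC(=O)c3ccc(Cl)c(Cl)c3)cc12`. Its change from compound 1 is 4-methylpiperazin-1-yl in place of (2-(diethylamino)ethyl)amino on an aromatic carbon.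

Going by the values given here, none of the measured steps touches this position. Among the compounds with values here, the single step recorded, a 3.3-fold higher number from compound 2 to compound 3 (0.52 log units; beyond the scatter), concerns the group on the carbonyl carbon and not the amine on the aromatic carbon, so it gives no direct guide. Compounds 2 and 3 carry a piperazinyl group at that place and both give higher numbers than compound 1, but each also differs from compound 1 on the carbonyl side, so their values cannot be separated into the two contributions. Within the data shown here, what can be read is only that the one compound with the open-chain amine and the dichlorophenyl amide sits lowest.

Against that background a modest rise in the number is expected for compound 4, a 1.8-fold higher number from compound 1 to compound 4 (0.25 log units; within the scatter), with wide uncertainty. The estimate for compound 4 in this assay is therefore 2500 nM, within 900 nM to 7000 nM.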

Compound 4, half-maximal inhibitory concentration: 3000 nM
For compound 4 the middle estimate is 1.2-fold (0.08 log units) below the measured one; measured number inside the range.
By their numbers in this assay, from the lowest: compound 1; then compounds 4 and 2 (each within the scatter of the next); then compound 3.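

Going by these compounds alone, with the dichlorophenyl amide held constant, compound 1 and compound 4 give the first direct reading of this position in this assay: a 2.1-fold higher number from compound 1 to compound 4 (0.32 log units; beyond the scatter). Replacing the open chain (2-(diethylamino)ethyl)amino with the 4-methylpiperazin-1-yl ring on the aromatic carbon next to the ring nitrogen therefore has a modest but real effect on the number, so the position accepts this ring and the two groups are not equivalent. The change alters the ring content and hydrogen-bond donor count together, and no measurement in hand bears on what lies behind the step.

From the compounds shown here alone, it remains open whether a step of this size would carry over to the 4-fluorophenyl and 2-methoxyphenyl amides, since this single pair holds only the dichlorophenyl amide constant. The compounds shown also leave open how other amines would read at this aromatic carbon, for example a morpholin-4-yl ring, an unsubstituted piperazin-1-yl ring, or a longer (3-(diethylamino)propyl)amino chain.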